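A halogen swap on the aryl group of compound 3

The compounds below may be only part of what the source reports. "The series", "measured", "known", "first", "only" and "open" are said of these compounds alone.

Three related compounds have been measured in a physicochemical assay for lipophilicity; a higher number here means a more lipophilic compound, a lower number a more polar compound. Compound 1 `COc1cc(C2=NO[C@]3(C2)C(=O)O[C@@H]2[C@H]3CC[C@H](C)[C@]3(O)C=CC(=O)[C@@]23C)ccc1O` gives 0.75 and compound 2 `Cc1ccccc1C1=NO[C@]2(C1)C(=O)O[C@@H]1[C@H]2CC[C@H](C)[C@]2(O)C=CC(=O)[C@@]12C` gives 1.86 as its reading. Compound 3 `C[C@H]1CC[C@@H]2[C@@H](OC(=O)[C@]23CC(c2ccc(Cl)cc2)N(c2ccccc2)O3)[C@]2(C)C(=O)C=C[C@@]12O` stands highest of the three with 3.87 as its reading, above compound 2 and further above compound 1.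

Compound 4 `C[C@H]1CC[C@@H]2[C@@H](OC(=O)[C@]23CC(c2c(F)cccc2F)N(c2ccccc2)O3)[C@]2(C)C(=O)C=C[C@@]12O` differs from compound 3 by 2,6-difluorophenyl in place of 4-chlorophenyl on a saturated ring carbon with 2,6-difluorophenyl in place of 4-chlorophenyl on a saturated ring carbon, next to the ring nitrogen.

For the measured compounds named here, only one measured step offers guidance, and it is large: a number 1.11 log units higher from compound 1 to compound 2 (beyond the scatter) with 2-methylphenyl in place of 4-hydroxy-3-methoxyphenyl on a carbon with a double bond to nitrogen. Going by the values given here, it involves different groups at a different place, and no measured pair tests this swap directly. Since a halogen-bearing phenyl leaves and another enters, a far smaller step is expected here. A modest fall is expected, with a number 0.37 log units lower from compound 3 to compound 4 (beyond the scatter) as the estimated step. In this assay compound 4 is estimated at 3.5 (expected range 3 to 4).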

Compound 4, partition coefficient: 3.42
Compound 4: middle estimate off by 0.08 log units, on the high side; the range from low to high includes it.
By their numbers in this assay, from the lowest: compound 1; then compound 2; then compound 4; then compound 3.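

In this assay, the saturated ring carbon next to the ring nitrogen proves sensitive to a change of aryl group: 2,6-difluorophenyl in place of 4-chlorophenyl gives a number 0.45 log units lower from compound 3 to compound 4 (beyond the scatter) in this first measured step at this position. The shift is beyond the scatter even though both groups hold one six-membered aromatic ring of carbon only, with no hydrogen-bond donors or acceptors and no net charge, and the entering group has the larger heavy-atom count. Nothing measured here accounts for the fall.

Going by these compounds, whether the fall follows the loss of the chlorine or the entry of the two fluorines stays open, and a plain phenyl or a 4-fluorophenyl group on this carbon would bear on that. How a phenyl carrying an amine or a carboxylic acid would read at this carbon is equally unsettled.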